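Aryl variation on the shared core: outlook for compound 3

The compounds below may be only part of what the source reports. "The series", "measured", "known", "first", "only" and "open" are said of these compounds alone.

Measured so far:
compound 1 `c1ccc2c(-c3cn4ccnc4c(-c4ccc5ncn(C6CCCCC6)c5c4)n3)cccc2c1` — 4.43%
compound 2 `Clc1ccc(-c2cn3ccnc3c(-c3ccc4ncn(C5CCCCC5)c4c3)n2)cc1` — 11.1%

In a functional assay on NCI/ADR-RES cells (Homo sapiens) for inhibition, read by sulforhodamine B assay, with a stated time of 48 h, tested at 10 uM (on this read-out higher numbers stand for more inhibition at the one concentration tested (going by the name of the read-out) and lower numbers for less inhibition), compound 2 gives 11.1%. The step of a number 6.7 percentage points higher from compound 1 to compound 2 (within the scatter) is within the scatter, so compound 1 and compound 2 are not told apart on this read-out; both numbers are low.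

Compound 3 `COc1ccccc1-c1cn2ccnc2c(-c2ccc3ncn(C4CCCCC4)c3c2)n1` differs from compound 2 by 2-methoxyphenyl in place of 4-chlorophenyl on an aromatic carbon.

Among the measured compounds shown here, the one measured step concerns the same place on the shared core and stayed within the scatter. It therefore gives no ground to expect a change beyond the scatter when a third group sits at that place. Compound 3 is accordingly estimated at 10%, with an expected range from 0% to 25%. The step this estimate means is a number 1.1 percentage points lower from compound 2 to compound 3 (within the scatter), expected to remain within the scatter.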

Compound 3, a percentage reported as inhibition, at one concentration (the size of the read-out at that concentration, not a potency): 0.06%
Compound 3: the middle estimate sits 9.9 percentage points above what was measured, within the range that was stated.
By their numbers in this assay, from the lowest: compounds 3, 1 and 2 (each within the scatter of the next, the first and the last beyond it).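

In this assay this position on the shared core now gives its first step beyond the scatter, a number 11 percentage points lower from compound 2 to compound 3 (beyond the scatter) on exchanging 4-chlorophenyl for 2-methoxyphenyl. Among the compounds shown here, the same entering group set against naphthalen-1-yl gives a number 4.4 percentage points lower from compound 1 to compound 3 (within the scatter) and so does not separate those two compounds, which leaves compound 2 and compound 3 as the only pair told apart here, while compound 1 is told apart from neither. No measured information available here accounts for this separation.

Going by these compounds, all three groups at this place hold a six-membered aromatic ring of carbon only, and all three numbers are low, so it remains open whether an amine or a carboxylic acid on that ring would give a clearly higher number. The single-concentration read-out also leaves the potency of all three compounds open.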